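Adding a Second Chloro to a Weakly Cytotoxic Sulfonylurea Analogue

This account rests on a few compounds, and the source may have more. Where it says the series, first, only, none or still open, it means among the compounds named here.

Compound 1 `O=C1c2ccccc2N(Cc2cccc(Cl)c2)S(=O)(=O)N1Cc1ccccc1` gives 2100000 nM in a functional assay on CCRF-CEM cells (Homo sapiens) for inhibition (a lower number here means that less compound is tolerated, a higher number that more compound is tolerated), the highest of the two numbers shown. Compound 2 `O=S1(=O)N=C(OCc2ccccc2)c2ccccc2N1Cc1ccc(Cl)c(Cl)c1`, built on a different core, gives 30500 nM in this assay, a gap well beyond the scatter. Compound 3 `O=C1c2ccccc2N(Cc2ccc(Cl)c(Cl)c2)S(=O)(=O)N1Cc1ccccc1` differs from compound 1 only by chloro in place of hydrogen on an aromatic carbon. Going by the values given here, no measured pair isolates such a change here, so compound 3 is expected to tolerate somewhat less compound than compound 1, with the step of a 3.0-fold lower number from compound 1 to compound 3 (0.48 log units; beyond the scatter) estimated as modest. Compound 3 is therefore expected to give about 700000 nM in this assay, likely between 150000 nM and 3000000 nM.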

Compound 3, half-maximal cytotoxic concentration: 16400 nM
Compound 3: the middle estimate sits 43-fold (1.63 log units) above what was measured, outside the stated range (below it).
By their numbers in this assay, from the lowest: compounds 3 and 2 (each within the scatter of the next); then compound 1.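

In this assay, chloro in place of hydrogen on this aromatic carbon, ortho to a chloro group and para to a large group, gives a 130-fold lower number from compound 1 to compound 3 (2.11 log units; beyond the scatter) as 3-chlorobenzyl becomes 3,4-dichlorobenzyl. The earlier compounds shown here held no step that isolated this position, and it now shows that one added chlorine here can shift the read-out strongly on the shared core. Nothing available explains the size of this step.

On these data alone, whether fluoro, methyl or methoxy on this carbon would give a step of similar size remains open. So does whether the same step would hold with an amine on the other benzyl group.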